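Where the Chlorine Sits: From Compound 1 to Compound 4

The source may report more compounds than this note shows. Statements on the series, on what has been measured and on what is new or still open speak of the compounds shown alone.

Compound 1, `O=C1NC(=O)C(Cc2ccc(Oc3cccc(Cl)c3)cc2)S1`: 318 nM
Compound 2, `O=C1NC(=O)C(Cc2ccc(Oc3cccc(C(F)(F)F)n3)cc2)S1`: 1640 nM
Compound 3, `O=C1NC(=O)C(Cc2ccc(Oc3cc(Cl)cc(Cl)c3)cc2)S1`: 207 nM

Of the compounds shown here, three have been measured in a functional assay for agonist activity at Free fatty acid receptor 1 (Homo sapiens), read by FLIPR, in the presence of a further agent that is not named here; a higher number here means that more compound is needed for the effect, a lower number that less compound is needed. Compound 1 stands second highest of the three numbers. Its nearest neighbour is compound 3, which gives 207 nM; the step of a 1.5-fold lower number from compound 1 to compound 3 (0.19 log units; within the scatter) lies within the scatter. The furthest is compound 2, which gives 1640 nM, the highest number of the three and clearly separated from compound 1; the two differ in more than one place, so only the two values themselves can be compared.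

Compound 4, `O=C1NC(=O)C(Cc2ccc(Oc3ccccc3Cl)cc2)S1`, has not yet been measured. It differs from compound 1 by 2-chlorophenyl in place of 3-chlorophenyl on an oxygen on an aromatic ring. Among the compounds with values here, the only measured step on the same ring is a 1.5-fold lower number from compound 1 to compound 3 (0.19 log units; within the scatter), which adds a chloro group rather than moving one, and was within the scatter. Nothing measured here speaks directly to a shift of the chlorine from one position to another, so the direction of any change is uncertain. The account therefore expects the step of a 1.6-fold higher number from compound 1 to compound 4 (0.20 log units; within the scatter) to be modest, and compound 4 is estimated at 500 nM, with a range from 200 nM to 1500 nM.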

Compound 4, half-maximal effective concentration: 1190 nM
Compound 4: the middle estimate sits 2.4-fold (0.38 log units) below what was measured; low and high end bracket the measured number.
By their numbers in this assay, from the lowest: compounds 3 and 1 (each within the scatter of the next); then compounds 4 and 2 (each within the scatter of the next).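

In this assay, within the data shown here, the position of the chlorine proves to matter, which the earlier compounds could not show: the step of a 3.7-fold higher number from compound 1 to compound 4 (0.57 log units; beyond the scatter) clears the scatter, whereas adding a second chloro group, the step of a 1.5-fold lower number from compound 1 to compound 3 (0.19 log units; within the scatter), did not. The group that leaves and the group that enters have the same atoms and the same counts, so this step separates 2-chlorophenyl from 3-chlorophenyl on the oxygen by the placement of the chlorine alone, with no change in composition. No measurement at hand gives a reason for the higher number that comes with 2-chlorophenyl.

The compounds shown leave open whether the step belongs to chlorine itself or would also appear with a fluoro, a methyl or a methoxy group standing where the chlorine stands in 2-chlorophenyl. They also leave open whether a second chloro group on the 2-chlorophenyl ring of compound 4 would leave its number within the scatter, as the second chloro group did in going from the 3-chlorophenyl ring of compound 1 to compound 3.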